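The source may report more compounds than this note shows. Statements on the series, on what has been measured and on what is new or still open speak of the compounds shown alone.

Compound 1 `COc1ccc(/C=C/c2ccc3ccccc3c2)cc1N`: 1820 nM
Compound 2 `COc1cc(/C=C/c2ccc3ccccc3c2)cc([N+](=O)[O-])c1OC`: > 10000 nM
Compound 3 `COc1cc(/C=C/c2ccc3ccccc3c2)cc(N)c1OC`: not yet measured

Readings come from a functional assay on A549 cells (Homo sapiens) for inhibition; a lower number here means a stronger inhibitor, a higher number a weaker inhibitor. Compound 1 gives a true number there, 1820 nM.

Compound 2 reads > 10000 nM, which is a limit of the assay and not a number. Its real position is therefore unknown, and any step starting from it can only be sized loosely.

Compound 3 has amino in place of nitro on an aromatic carbon, ortho to a methoxy group: amino in place of nitro on an aromatic carbon. Going by the values given here, no measured pair isolates this change, so the expectation rests on thin ground. Among the compounds with values here, the one available pointer is compound 1, which also carries an amino group and gives 1820 nM. A clear move toward stronger inhibition is therefore expected, though compound 3 could still stay at the limit.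

The estimated step is an at least 4.0-fold lower number from compound 2 to compound 3 (0.60 log units; beyond the scatter).

For compound 3 the expected value is 2500 nM, with an estimated range from 500 nM to 10000 nM.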

Compound 3, half-maximal inhibitory concentration: 2150 nM
Compound 3: middle estimate off by 1.2-fold (0.07 log units), on the high side, and the stated range covers the measured number.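

In this assay, going by these compounds alone, amino in place of nitro on an aromatic carbon, ortho to a methoxy group, gives an at least 4.6-fold lower number from compound 2 to compound 3 (0.66 log units; beyond the scatter), the first pair to isolate this change. Compound 2 reads > 10000 nM, which is a limit and not a number, so the step has a minimum size but no known true size: the limit of > 10000 nM in this assay, at which 1 of the 3 values shown sits. With the amino group present, methoxy in place of hydrogen on an aromatic carbon gives a 1.2-fold higher number from compound 1 to compound 3 (0.07 log units; within the scatter), so this added methoxy group leaves compound 3 within the scatter of compound 1 in this assay.

The series therefore shows that the amino compounds give true numbers, but not whether an amino group specifically is required at this carbon, since a hydroxyl group, an acetamide or a dimethylamino group there remains an open comparison. Also open, from the compounds shown here alone, is how a compound with hydrogen in place of the amino group would read on the shared core, which would show how much of the reading depends on having any substituent at this carbon.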